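The source may hold more compounds than are shown below. What is called first, only, known or untested is meant among the compounds shown, and "the series" means these compounds.

Measured so far in a functional assay on A549 cells (Homo sapiens) for antiproliferative activity, read by MTT assay, with a stated time of 72 h; a higher number here means a weaker inhibitor, a lower number a stronger inhibitor:
compound 1 `CCC(=O)N(C)c1ccc2[nH]c(-c3n[nH]c4ccccc34)cc2n1` gives 15700 nM
compound 2 `CN(C(=O)c1ccco1)c1ccc2[nH]c(-c3n[nH]c4ccccc34)cc2n1` gives 15500 nM

Compound 2 sits at the lowest of the two numbers in this assay, but compound 1 stands within the scatter of it, so the two are not told apart. Compound 3 `CN(c1ccc2[nH]c(-c3n[nH]c4ccccc34)cc2n1)S(=O)(=O)c1ccccc1` is still unmeasured; it differs from compound 2 by phenylsulfonyl in place of (furan-2-yl)carbonyl on a nitrogen on an aromatic ring. Among the measured compounds shown here, the only step that bears on this change, a swap of the group carried on that nitrogen, is a 1.0-fold lower number from compound 1 to compound 2 (0.01 log units; within the scatter), which moved nothing beyond the scatter. For compound 3 the expected step in this assay is therefore a 1.0-fold lower number from compound 2 to compound 3 (0.01 log units; within the scatter), and its estimated value is 15000 nM, within 6000 nM to 40000 nM.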

Compound 3, half-maximal inhibitory concentration: 14000 nM
The estimate for compound 3 lay 1.1-fold (0.03 log units) above the measured number, and the stated range covers the measured number.
By their numbers in this assay, from the lowest: compounds 3, 2 and 1 (each within the scatter of the next).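

In this assay, replacing the carbonyl link on this nitrogen with a sulfonyl link bearing a phenyl ring gives a 1.1-fold lower number from compound 2 to compound 3 (0.04 log units; within the scatter) and, starting from the propanoyl group, a 1.1-fold lower number from compound 1 to compound 3 (0.05 log units; within the scatter). The earlier insensitivity to the group on this nitrogen therefore holds not only when the group on the carbonyl changes, but also when the carbonyl itself is replaced. Nothing available here explains this lack of response. Still open, as far as these compounds go, is whether a group on this nitrogen ending in an amine or a carboxylic acid would move the number beyond the scatter.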